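The source may report more compounds than this note shows. Statements on the series, on what has been measured and on what is new or still open speak of the compounds shown alone.

Three compounds share the core of compound 1 `CCOc1ccc2c(=O)c(-c3ccc(O)cc3)coc2c1` and have been compared in an assay on isolated protein (Cricetulus griseus) for inhibition of aldehyde dehydrogenase, mitochondrial (Homo sapiens); a lower number here means a stronger inhibitor, a higher number a weaker inhibitor. Compound 1 gives 40 nM. Compound 2 `O=c1c(-c2ccc(O)cc2)coc2cc(OCCCCCCBr)ccc12` gives 300 nM, and compound 3 `O=c1c(-c2ccc(O)cc2)coc2cc(OCCCBr)ccc12` gives 260 nM. Compound 2 stands at the highest number of the three; the nearest of the others is reached by a 1.2-fold lower number from compound 2 to compound 3 (0.06 log units; within the scatter), and the furthest by a 7.5-fold higher number from compound 1 to compound 2 (0.88 log units; beyond the scatter). Compound 4 `O=C(O)CCCCCCCCCOc1ccc2c(=O)c(-c3ccc(O)cc3)coc2c1` differs from compound 2 by 3-carboxypropyl in place of bromo on a saturated chain carbon, six bonds along the chain from an oxygen on an aromatic ring. Among the measured compounds shown here, no measured step trades bromo for a carboxypropyl group. For the measured compounds named here, the steps that bear on it are those that lengthen the chain on the aromatic oxygen, a 7.5-fold higher number from compound 1 to compound 2 (0.88 log units; beyond the scatter) and a 6.5-fold higher number from compound 1 to compound 3 (0.81 log units; beyond the scatter), both modest and in the same direction, while a 1.2-fold lower number from compound 2 to compound 3 (0.06 log units; within the scatter) shows that the length of the bromoalkyl chain itself makes no difference beyond the scatter. On that footing compound 4 is expected to stay close to compound 2, with an estimated step of a 1.1-fold higher number from compound 2 to compound 4 (0.03 log units; within the scatter) that may well lie within the scatter. The estimate for compound 4 in this assay is 320 nM, with a range from 110 nM to 1000 nM.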

Compound 4, half-maximal inhibitory concentration: 4 nM
The estimate for compound 4 lay 80-fold (1.90 log units) above the measured number, and the stated range ends above it.
By their numbers in this assay, from the lowest: compound 4; then compound 1; then compounds 3 and 2 (each within the scatter of the next).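

In this assay, the end of the chain on the aromatic oxygen proves to matter far more than the two bromo compounds could show: 3-carboxypropyl in place of bromo gives a 75-fold lower number from compound 2 to compound 4 (1.88 log units; beyond the scatter), and the matching change on the shorter chain gives a 65-fold lower number from compound 3 to compound 4 (1.81 log units; beyond the scatter). Adding a chain at this position therefore does not by itself weaken inhibition, since the chain ending in a carboxylic acid also gives a 10-fold lower number from compound 1 to compound 4 (1.00 log units; beyond the scatter), opposite in direction to the steps seen with both bromo chains. No evidence is available here that explains this reversal.

As far as these compounds go, compound 4 differs from compound 2 in both chain length and chain end, so the share of each remains open. Whether a shorter chain ending in a carboxylic acid, or a chain of the same length ending in an ester or an amide, would give a similar number also remains unresolved.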